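A few compounds are considered here, and "the series" means these few. Any claim that something is new, unique, unknown or untested is made for them only; others in the source may bear on it.

Measured compounds:
- compound 1, `C=C1CC[C@H]2[C@@](C)(CCC(=O)N[C@@]2(C)COC(=O)c2ccc([N+](=O)[O-])cc2)[C@@H]1/C=C/C1=CCOC1=O`; in a functional assay on RAW264.7 cells (Mus musculus) for inhibition, read by Griess assay, with stated times of 3 h and 24 h (a higher number here means a weaker inhibitor, a lower number a stronger inhibitor), compound 1 gives 33500 nM.
- compound 2, `C=C1CC[C@H]2[C@@](C)(CCC(=O)N[C@@]2(C)COC(=O)[C@H](N)CC(C)C)[C@@H]1/C=C/C1=CCOC1=O`; in this assay compound 2 reaches only the limit > 50000 nM.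
- compound 3, `C=C1CC[C@H]2[C@@](C)(CC[C@@H](OC(=O)c3ccc([N+](=O)[O-])cc3)[C@@]2(C)NC=O)[C@@H]1/C=C/C1=CCOC1=O`; in this assay compound 3 likewise reaches only the limit > 50000 nM.

Working notes. Compound 1 and compound 2 share a core and differ by 1-amino-3-methylbutyl in place of 4-nitrophenyl on a carbonyl carbon. That change gave an at least 1.4-fold higher number from compound 1 to compound 2 (0.17 log units; that floor lies within the scatter). Because compound 2 sits at the limit of > 50000 nM in this assay, at which 2 of the 3 values shown sit, the step is known only as a floor, and the floor itself is within the scatter, so the change reads as neutral to weakly unfavourable at best.

Compound 3 carries the same atoms as compound 1 joined differently; the difference between the two cores is not broken down here. Compound 4, `C=C1CC[C@H]2[C@@](C)(CC[C@@H](OC(=O)[C@H](N)CC(C)C)[C@@]2(C)NC=O)[C@@H]1/C=C/C1=CCOC1=O`, is not yet measured and stands to compound 3 exactly as compound 2 stands to compound 1, namely by 1-amino-3-methylbutyl in place of 4-nitrophenyl on a carbonyl carbon. The place is the same in both pairs, a carbonyl carbon whose other neighbour is oxygen next to a carbonyl group, so this is the same change.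

The expectation for compound 4 in this assay rests on compound 3 already sitting at the limit > 50000 nM and on the earlier step of an at least 1.4-fold higher number from compound 1 to compound 2 (0.17 log units; that floor lies within the scatter) giving no sign of a gain. The step from compound 3 to compound 4 is therefore estimated as a step that the limit leaves unreadable from compound 3 to compound 4, most likely another limit rather than a number. Compound 4 is estimated at 90000 nM, with a range of 40000 nM to 400000 nM.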

Compound 4, half-maximal inhibitory concentration: > 50000 nM
Compound 4 was reported as a limit; the forecaster's own chance of this, stated with the estimate: 85%; the middle value is on the limit's open side.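

In this assay compound 4 gives > 50000 nM, which is a limit of the assay. Within the data shown here, compound 3 gives > 50000 nM, also a limit, so no step between compound 3 and compound 4 can be read. The compounds shown leave open whether 1-amino-3-methylbutyl in place of 4-nitrophenyl on a carbonyl carbon changes the inhibition on either core by any amount.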